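This account rests on a few compounds, and the source may have more. Where it says the series, first, only, none or still open, it means among the compounds named here.

Compound 3 `COc1ccc(NC(=O)c2ccc(CNc3nccc(-c4cccnc4)n3)cc2)c(N)c1` stands at a limit in an assay for inhibition of histone deacetylase 8 (Homo sapiens), read by fluorescence, with stated times of 15 min and 60 min (a higher number here means a weaker inhibitor, a lower number a stronger inhibitor), giving > 20000 nM. Compound 1 `Nc1cc(O)ccc1NC(=O)c1ccc(CNc2nccc(-c3cccnc3)n2)cc1` also gives only a limit, > 20000 nM. Compound 2 `Nc1cc(C(=O)O)ccc1NC(=O)c1ccc(CNc2nccc(-c3cccnc3)n2)cc1` likewise reaches only a limit, > 20000 nM. All three values sit at the limit of > 20000 nM in this assay, at which 3 of the 3 values shown sit. Compound 4 `O=C(NO)c1ccc(CNc2nccc(-c3cccnc3)n2)cc1` differs from compound 3 by hydroxy in place of 2-amino-4-methoxyphenyl on an amide-type nitrogen. Among the compounds with values here, the measured steps that bear on it are a step that the two limits leave unreadable from compound 1 to compound 2, a step that the two limits leave unreadable from compound 1 to compound 3 and a step that the two limits leave unreadable from compound 2 to compound 3, and none of them yields a size, so no measured step calibrates the present change. The expected step of an at least 33-fold lower number from compound 3 to compound 4 (1.52 log units; beyond the scatter) therefore rests on the structural change alone and is taken as a move toward stronger inhibition. Compound 4 is expected to give about 600 nM, within a range of 100 nM to 5000 nM.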

Compound 4, half-maximal inhibitory concentration: 410 nM
The estimate for compound 4 lay 1.5-fold (0.17 log units) above the measured number; the range from low to high includes it.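

With hydroxy on the amide-type nitrogen, the series gains a readable value in this assay, and the change from each substituted phenyl group is large: an at least 48-fold lower number from compound 3 to compound 4 (1.68 log units; beyond the scatter), an at least 48-fold lower number from compound 2 to compound 4 (1.68 log units; beyond the scatter) and an at least 48-fold lower number from compound 1 to compound 4 (1.68 log units; beyond the scatter). These sizes are lower bounds, because the other three compounds give only a limit: the limit of > 20000 nM in this assay, at which 3 of the 4 values shown sit. The steps among compound 1, compound 2 and compound 3 cannot be read, so the ring substituents remain unranked.

As far as these compounds go, whether the gain belongs to hydroxy itself or to the loss of the substituted phenyl group stays open. An amino group or a methyl on the amide-type nitrogen would separate the two.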